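Aryl swap on an aromatic nitrogen in an antiproliferation series

The source may hold more compounds than are shown below. What is called first, only, known or untested is meant among the compounds shown, and "the series" means these compounds.

Compound 1 `Cc1ccccc1-n1nncc1CN1C(=O)C2(C(C#N)=C(N)Oc3c2c2nc4ccccc4nc2c2ccccc32)c2ccccc21` and compound 2 `N#CC1=C(N)Oc2c(c3nc4ccccc4nc3c3ccccc23)C12C(=O)N(Cc1cnnn1-c1ccc(S(N)(=O)=O)cc1)c1ccccc12` share one core and differ only in the aryl group carried on an aromatic nitrogen. In an ADME assay on HUVEC cells (Homo sapiens) for antiproliferative activity, read by MTT assay, with a stated time of 48 h (a lower number here means a stronger inhibitor, a higher number a weaker inhibitor), compound 1 gives > 50000 nM, which is a limit of the assay and not a number. In this assay compound 2 gives > 50000 nM, again a limit rather than a number. The step that the two limits leave unreadable from compound 1 to compound 2 therefore cannot be sized. Compound 2 thus stands at the limit of > 50000 nM in this assay, at which 2 of the 2 values shown sit, and nowhere more exact. Compound 3 `Cc1ccc(-n2nncc2CN2C(=O)C3(C(C#N)=C(N)Oc4c3c3nc5ccccc5nc3c3ccccc43)c3ccccc32)cc1C` carries the next change: 3,4-dimethylphenyl in place of 4-sulfamoylphenyl on an aromatic nitrogen. Going by the values given here, the only measured step that bears on this place is the unreadable one, so it sets no direction or size. Compound 1 also sits at the limit of > 50000 nM in this assay, at which 2 of the 2 values shown sit, with a methylphenyl group on that nitrogen. Compound 3 is therefore expected to give about 60000 nM, within 15000 nM to 250000 nM, most likely reported again only as a limit. The expected step that the limit leaves unreadable from compound 2 to compound 3 is accordingly none beyond the scatter.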

Compound 3, half-maximal inhibitory concentration: > 50000 nM
Compound 3: a limit, no number; the forecaster's own chance of this, stated with the estimate: 80%; the middle value does not contradict the limit.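

Compound 3, like compound 1 and compound 2, gives only a limit and not a number, so the steps from compound 1 and compound 2 to compound 3 cannot be read: the limit of > 50000 nM in this assay, at which 3 of the 3 values shown sit.

These compounds leave open whether swapping the aryl group on that aromatic nitrogen changes antiproliferative activity at all.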